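Phenyl in place of ethyl in a cytotoxic series

The source may report more compounds than this note shows. Statements on the series, on what has been measured and on what is new or still open speak of the compounds shown alone.

Values in a functional assay on DU-145 cells (Homo sapiens) for cytotoxicity, read by MTT assay; on this read-out higher numbers stand for weaker inhibition and lower numbers for stronger inhibition:
- compound 1 `CCCCCCC(C)(O)CC(=O)O[C@H](CC=C(C)C)C1=CC(=O)c2c(O)ccc(O)c2C1=O`: > 100000 nM (a limit)
- compound 2 `CC[C@@](C)(O)CC(=O)O[C@H](CC=C(C)C)C1=CC(=O)c2c(O)ccc(O)c2C1=O`: 12700 nM
- compound 3 `CCC(C)(O)CC(=O)O[C@H](CC=C(C)C)C1=CC(=O)c2c(O)ccc(O)c2C1=O`: 16000 nM
- compound 4 `CC(C)=CC[C@@H](OC(=O)CC(C)(O)c1ccccc1)C1=CC(=O)c2c(O)ccc(O)c2C1=O`: not yet measured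

Compound 3 sits level with compound 2, as the step of a 1.3-fold higher number from compound 2 to compound 3 (0.10 log units; within the scatter) shows, and that pair differs only in the fact that one of compounds 2 and 3 is drawn with a defined configuration and the other without, at the place where they differ. The value of compound 1 is a limit. Compound 4 departs from compound 3 at one place: phenyl in place of ethyl on a saturated chain carbon bound to an oxygen on a saturated carbon and two saturated chain carbons. The nearest guide is the longer substituent of compound 1, seen in the steps of an at least 7.8-fold lower number from compound 1 to compound 2 (0.89 log units; beyond the scatter) and an at least 6.2-fold lower number from compound 1 to compound 3 (0.79 log units; beyond the scatter), whose sizes rest on (the limit of > 100000 nM in this assay, at which 1 of the 3 values shown sits). For the measured compounds named here, those steps show that the larger group goes with the higher number in this assay, though only for an open chain, and no measured compound carries a ring at this place. A modest rise is therefore expected, with the estimated step being a 1.6-fold higher number from compound 3 to compound 4 (0.19 log units; within the scatter). For compound 4 the expected value is 25000 nM, with an estimated range of 9000 nM to 80000 nM.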

Compound 4, half-maximal inhibitory concentration: > 100000 nM
Compound 4: no number, only a limit; the forecaster's own chance of this, stated with the estimate: 20%; at least 4.0-fold (0.60 log units) between middle value and limit.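

In this assay, phenyl in place of ethyl gives an at least 6.2-fold higher number from compound 3 to compound 4 (0.79 log units; beyond the scatter), and the change from 1-hydroxy-1-methylpropyl to 1-hydroxy-1-phenylethyl gives an at least 7.8-fold higher number from compound 2 to compound 4 (0.89 log units; beyond the scatter). The earlier compounds shown here linked a readable value's loss only to an open chain, the hexyl of compound 1, whereas compound 4 shows that a six-membered aromatic ring at this place also ends at a limit and not at a number. The step from compound 1 to compound 4 cannot be read, and the two steps just given rest on a limit: the limit of > 100000 nM in this assay, at which 2 of the 4 values shown sit.

The compounds shown leave open how much of a group this place tolerates, since nothing lies between ethyl and phenyl or hexyl. A propyl chain or a cyclopropyl ring could show where a readable value ends, and a pyridyl ring could show whether any aromatic ring here behaves as phenyl does.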